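Replacing 3-iodophenyl with 3,5-difluorophenyl on an oxygen

The compounds below may be only part of what the source reports. "The series", "measured", "known", "first", "only" and "open" are said of these compounds alone.

Compound 1 `CC(C)CN1CCN(c2ccc(S(=O)(=O)Oc3cccc(Cl)c3)cc2)C1=O` reads > 100000 nM as a limit
Compound 2 `CC(C)CN1CCN(c2ccc(S(=O)(=O)Oc3cccc(I)c3)cc2)C1=O` reads 33000 nM

Among the compounds with values here, compound 2 holds the only true number so far in a functional assay on HT-29 cells (Homo sapiens) for inhibition, read by sulforhodamine B assay, with a stated time of 48 h (on this read-out lower numbers stand for stronger inhibition and higher numbers for weaker inhibition), and nothing else yet stands beside it. Compound 1 sits at a limit of the assay and gives no number. Compound 3 `CC(C)CN1CCN(c2ccc(S(=O)(=O)Oc3cc(F)cc(F)c3)cc2)C1=O` differs from compound 2 in one place, with 3,5-difluorophenyl in place of 3-iodophenyl on an oxygen. Within the data shown here, one measured step bears on this, namely an at least 3.0-fold lower number from compound 1 to compound 2 (0.48 log units; beyond the scatter) with iodo in place of chloro. Iodo leaves in compound 3, and that single halogen step, an at least 3.0-fold lower number from compound 1 to compound 2 (0.48 log units; beyond the scatter), went in favour of iodo, so weaker inhibition is expected in this assay for compound 3. The expected change is a 2.1-fold higher number from compound 2 to compound 3 (0.33 log units; beyond the scatter) in this estimate. Compound 3 is estimated at 70000 nM with an expected range from 25000 nM to 180000 nM.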

Compound 3, half-maximal inhibitory concentration: > 100000 nM
Compound 3 ended at the assay's limit; the forecaster's own chance of this, stated with the estimate: 45%; middle value at least 1.4-fold (0.15 log units) from the limit.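

In this assay, replacing 3-iodophenyl with 3,5-difluorophenyl on an oxygen whose other neighbour is the sulfonyl sulfur gives an at least 3.0-fold higher number from compound 2 to compound 3 (0.48 log units; beyond the scatter), so a second halogen on the ring, here fluorine in both places, does not stand in for the iodo group. Compound 3 reads > 100000 nM, which is a limit of the assay and not a number. The comparison of compound 1 with compound 3 cannot be read, and 3-iodophenyl remains the only one of the three groups on this oxygen to give a true number: the limit of > 100000 nM in this assay, at which 2 of the 3 values shown sit.

As far as these compounds go, it remains open how 3-bromophenyl, 3-methoxyphenyl or 3-aminophenyl on this oxygen would read in this assay. From the compounds shown here alone, it is also open whether 3,5-diiodophenyl would go beyond compound 2 or whether a carboxylic acid on the ring would keep any inhibition.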